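The source may hold more compounds than are shown below. What is called first, only, known or untested is meant among the compounds shown, and "the series" means these compounds.

Measured compounds:
Compound 1, `COc1cc(OC)c(OC)cc1/C=C/COC(=O)/C=C/c1ccc(Br)cc1`: in a functional assay on the whole organism (strain Kunming) with Mus musculus as the target, with a stated time of 0.5 h, at a dose of 300 mg/kg by the intraperitoneal route (a lower number here means a stronger effect, a higher number a weaker effect of the compound at the dose given), compound 1 gives 100%.
Compound 2, `COc1cc(OC)c(OC)cc1/C=C/COC(=O)/C=C/c1ccccc1C(F)(F)F`: in this assay compound 2 gives 100%.

Compound 2 stands level with compound 1 at the digits shown. Within the data shown here, the one step measured between them, no change at the digits printed from compound 1 to compound 2 (within the scatter), places 2-(trifluoromethyl)phenyl where compound 1 carries 4-bromophenyl, and the read-out does not move beyond the scatter.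

Compound 3, `COc1cc(OC)c(OC)cc1/C=C/COC(=O)/C=C/c1cccc(Br)c1`, has not yet been measured in this assay. It differs from compound 2 in one place: 3-bromophenyl in place of 2-(trifluoromethyl)phenyl on a double-bonded chain carbon bound to a double-bonded chain carbon. Among the measured compounds shown here, the only step that bears on it is the one from compound 1 to compound 2, which also swaps the aromatic ring at the same place on the chain and leaves the read-out where it was. For the measured compounds named here, nothing among the measured compounds points to a change of any size or direction, so for compound 3 a step of a number 5 percentage points lower from compound 2 to compound 3 (within the scatter) is expected, which is none beyond the scatter. The estimate for compound 3 in this assay is therefore 95%, with a range from 78% to 100%.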

Compound 3, a percentage reported as activity, at one dose (the size of the read-out at that dose, not a potency): 100%
Estimate against measurement, compound 3: 5 percentage points below; the range from low to high includes it.
By their numbers in this assay, from the lowest: compounds 1, 2 and 3 (each within the scatter of the next).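

The exchange of 2-(trifluoromethyl)phenyl for 3-bromophenyl on a double-bonded chain carbon bound to a double-bonded chain carbon gives no change at the digits printed from compound 2 to compound 3 (within the scatter) in this assay and thus adds a third aromatic group to the two already compared at this place. The new information lies in the pair that keeps bromine on the ring and alters only its printed position, since 3-bromophenyl in place of 4-bromophenyl gives no change at the digits printed from compound 1 to compound 3 (within the scatter) in this assay and so separates the two bromophenyl groups by nothing that can be read here. Across these three compounds, then, neither the position of bromine nor the exchange of bromine for trifluoromethyl shifts the read-out, and nothing available explains this sameness.

The compounds shown leave open whether an aminophenyl or carboxyphenyl group at this place, or a plain phenyl ring without any substituent, would give a different read-out. They also leave open whether a longer chain between the ester and the aromatic ring, or a change within the shared core, would separate compounds that these aromatic exchanges do not.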